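Exchanging a Phenyl for a Chlorobenzyl on the Ring Nitrogen

The compounds below may be only part of what the source reports. "The series", "measured", "known", "first", "only" and "open" are said of these compounds alone.

Measured compounds:
compound 1 `Cc1ccc2oc(SCC(=O)Nc3ccc(-c4nc(-c5ccccc5)c(-c5ccccc5)n4C)cc3)nc2c1` with 22.4 ug/mL
compound 2 `Cn1c(-c2ccc(NC(=O)CSC3=NCCS3)cc2)nc(-c2ccccc2)c1-c1ccccc1` with 21 ug/mL
compound 3 `Cn1c(-c2ccc(NC(=O)CN3CCN(c4ccccc4)CC3)cc2)nc(-c2ccccc2)c1-c1ccccc1` with 8.6 ug/mL

Three compounds sharing one core were measured in a functional assay on HT-29 cells (Homo sapiens) for cytotoxicity, read by MTT assay, with a stated time of 24 h; on this read-out lower numbers stand for stronger inhibition and higher numbers for weaker inhibition. Compound 3 gives the lowest number of the three: it sits a 2.6-fold lower number from compound 1 to compound 3 (0.42 log units; beyond the scatter) and a 2.4-fold lower number from compound 2 to compound 3 (0.39 log units; beyond the scatter), both steps beyond the scatter, whereas a 1.1-fold lower number from compound 1 to compound 2 (0.03 log units; within the scatter) stays within it.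

Compound 4 `Cn1c(-c2ccc(NC(=O)CN3CCN(Cc4ccc(Cl)cc4)CC3)cc2)nc(-c2ccccc2)c1-c1ccccc1` is the next compound. It differs from compound 3 in one place: 4-chlorobenzyl in place of phenyl on an amine nitrogen in a ring. Among the measured compounds shown here, every measured step concerns the group on the saturated chain carbon bound to the carbonyl carbon, and none touches the group on the ring nitrogen itself; compound 4 keeps the same six-membered ring as compound 3, so no measured step bears directly on this exchange. He therefore expects in this assay no step beyond the scatter, which means compound 4 is estimated at 9 ug/mL, within a range of 4 ug/mL to 20 ug/mL. The expected step is a 1.0-fold higher number from compound 3 to compound 4 (0.02 log units; within the scatter).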

Compound 4, half-maximal inhibitory concentration: 12 ug/mL
The estimate for compound 4 lay 1.3-fold (0.12 log units) below the measured number; measured number inside the range.
By their numbers in this assay, from the lowest: compounds 3, 4, 2 and 1 (each within the scatter of the next, the first and the last beyond it).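

In this assay, among the compounds shown here, the earlier steps all exchanged the whole group on the saturated chain carbon, whereas this one keeps the six-membered ring with 2 nitrogen and changes only the group on its amine nitrogen. With a 1.4-fold higher number from compound 3 to compound 4 (0.14 log units; within the scatter) the exchange stays within the scatter, so 4-chlorobenzyl is tolerated in place of phenyl at this position in this assay. No evidence is available that would explain this result.

Because 4-chlorobenzyl differs from phenyl in both the benzyl carbon and the chlorine, the compounds shown cannot separate these two changes, which unsubstituted benzyl or 4-chlorophenyl would do. On these data alone, it also stays open how this nitrogen would respond to a group of another kind, such as a carboxylic acid on a longer chain.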